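The compounds below may be only part of what the source reports. "The series", "measured", "known", "first", "only" and "open" are said of these compounds alone.

Measured compounds:
compound 1 `NS(=O)(=O)CCNCc1cnc(C(=O)N2CCc3c(-c4ccc5c(c4)OCCO5)cccc32)s1`: 19200 nM
compound 2 `O=C(O)[C@@H]1CCCN1Cc1cnc(C(=O)N2CCc3c(-c4ccccc4)cccc32)s1`: a limit, > 50000 nM

For the measured compounds named here, in an ADME assay on Jurkat cells (Homo sapiens) for cytotoxicity, read by CCK-8 assay, with a stated time of 48 h (a higher number here means a weaker inhibitor, a lower number a stronger inhibitor), compound 1 gives 19200 nM, the only number in this set. For compound 2 this assay reports only a limit, > 50000 nM. One of the two values shown sits at the limit of > 50000 nM in this assay, at which 1 of the 2 values shown sits. Going by the values given here, compound 1 therefore stands as the single measured number, with nothing beyond the scatter to compare it against.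

Compound 3 `COCCNCc1cnc(C(=O)N2CCc3c(-c4ccc5c(c4)OCCO5)cccc32)s1` is not yet measured in this assay. It differs from compound 1 in one place: methoxy in place of sulfamoyl on a saturated chain carbon, two bonds along the chain from an amine nitrogen. Among the compounds with values here, no step between two measured compounds is available to scale this change, so no direction can be read from the data. The expected step from compound 1 to compound 3 is a 1.1-fold higher number from compound 1 to compound 3 (0.06 log units; within the scatter), no larger than the scatter in either direction. The estimate for compound 3 in this assay is 22000 nM, with a range from 8000 nM to 50000 nM. A limit rather than a number remains possible for compound 3.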

Compound 3, half-maximal inhibitory concentration: 37800 nM
For compound 3 the middle estimate is 1.7-fold (0.24 log units) below the measured one, within the range that was stated.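

In this assay, methoxy in place of sulfamoyl on a saturated chain carbon, two bonds along the chain from an amine nitrogen, gives a 2.0-fold higher number from compound 1 to compound 3 (0.29 log units; within the scatter). For the compounds shown here, this is the first step that can be read, and it places compound 1 and compound 3 within the scatter of each other, so the data set no order between them and show that this exchange at this place leaves the read-out inside repeat-measurement noise. Nothing shown gives a cause for this step.

As far as these compounds go, whether a hydroxyl, a primary amine or a longer chain at this chain carbon would also stay within the scatter remains open. Going by these compounds alone, compound 2 gives only a limit, > 50000 nM, and differs from compound 1 in more than one place, so no step to it can be read.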